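The compounds below may be only part of what the source reports. "The series", "measured", "known", "first", "only" and "open" are said of these compounds alone.

Values measured so far in an ADME assay on a cell-free system (plasma, Rattus norvegicus) for metabolic stability, read by LC-MS, with a stated time of 1 h, at 37 degrees C, tested at 100 uM; a lower number here means that less of the compound is left, a higher number that more of the compound is left
- compound 1 `O=C(O)c1cc(-c2cccc(COc3ccc4c(=O)n(CC5CC5)sc4c3)c2)ccc1Cl` gives 100%
- compound 2 `O=C1c2ccc(OCc3cccc(-c4ccccc4)c3)cc2CN1C1CCCC1` gives 95%
- compound 3 `CN(C)C(=O)c1cc(-c2cccc(COc3ccc4c(=O)n(C5CCCC5)sc4c3)c2)ccc1Cl` gives 100%

Compound 2, at 95%, lies within the scatter of both compound 1 and compound 3, so the three measured compounds cannot be separated on these numbers. Compound 4 `O=C(O)c1cc(F)cc(-c2cccc(COc3ccc4c(c3)CN(C3CCCC3)C4=O)c2)c1` has not yet been measured. Relative to compound 2, it carries 3-carboxy-5-fluorophenyl in place of phenyl on an aromatic carbon, meta to a large group (3-carboxy-5-fluorophenyl in place of phenyl on an aromatic carbon). For the measured compounds named here, no two measured compounds differ in one place only, so the data offer no direct step for this change. Compound 1, which also carries a carboxy group, gives 100% in this assay, and compound 3, which has none, gives 100% there too. On that basis, no shift beyond the scatter is expected for compound 4. The expected change is small, a number 2 percentage points higher from compound 2 to compound 4 (within the scatter) in the estimate. For compound 4 the estimated value is 97%, with an expected range from 85% to 100%.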

Compound 4, percent of the compound remaining: 95%
Beside the measured number, compound 4's estimate is 2 percentage points above it; low and high end bracket the measured number.
By their numbers in this assay, from the lowest: compounds 2, 4, 1 and 3 (each within the scatter of the next).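

In this assay, for the compounds shown here, replacing phenyl with 3-carboxy-5-fluorophenyl on an aromatic carbon, meta to a large group, gives the first direct reading for a single change: no change at the digits printed from compound 2 to compound 4 (within the scatter). Compounds 1, 2 and 3 differ in more than one place and could not isolate any one change, whereas this pair shows that this larger group, with its added hydrogen-bond donor and acceptor, leaves the read-out within the scatter at this position. The data shown offer no measurement that bears on why the number holds.

The compounds shown do not separate the carboxy group from the fluorine, since the two enter together. As far as these compounds go, whether an aminomethyl group or a nitrile on the same phenyl ring would read the same in this assay also remains open.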